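From isopropyl to isobutyl on an amine nitrogen

The source may report more compounds than this note shows. Statements on the series, on what has been measured and on what is new or still open speak of the compounds shown alone.

- Compound 1 `N=C(NC(=N)NC1CCCC1)Nc1ccc(C(F)(F)F)cc1`: 3300 nM
- Compound 2 `CC(C)NC(=N)NC(=N)Nc1ccc(C(F)(F)F)cc1`: 5200 nM

In a functional assay on UMUC3 cells (Homo sapiens) for antiproliferative activity, read by MTT assay, with a stated time of 72 h (a higher number here means a weaker inhibitor, a lower number a stronger inhibitor), compound 2 gives 5200 nM and compound 1 gives 3300 nM. The gap between these two values is a 1.6-fold higher number from compound 1 to compound 2 (0.20 log units; within the scatter), so compound 2 cannot be told apart from compound 1 in this test.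

Compound 3 `CC(C)CNC(=N)NC(=N)Nc1ccc(C(F)(F)F)cc1` has not yet been measured. It differs from compound 2 as follows: isobutyl in place of isopropyl on an amine nitrogen. In words, this is isobutyl in place of isopropyl on an amine nitrogen.

Among the compounds with values here, only one measured step bears on this change: a 1.6-fold higher number from compound 1 to compound 2 (0.20 log units; within the scatter), with isopropyl in place of cyclopentyl on an amine nitrogen. As that swap of one alkyl group for another stayed within the scatter, no step beyond the scatter is expected in this assay. The expected change is a 1.2-fold lower number from compound 2 to compound 3 (0.06 log units; within the scatter). For compound 3 the estimated value is 4500 nM, with an expected range of 2200 nM to 9000 nM.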

Compound 3, half-maximal inhibitory concentration: 2000 nM
Estimate against measurement, compound 3: 2.3-fold (0.35 log units) above, and the stated range ends above it.
By their numbers in this assay, from the lowest: compounds 3, 1 and 2 (each within the scatter of the next, the first and the last beyond it).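

Unlike the earlier swap of cyclopentyl for isopropyl, the change to isobutyl on this amine nitrogen moves the result past the scatter: in this assay there is a 2.6-fold lower number from compound 2 to compound 3 (0.41 log units; beyond the scatter), though the step is modest. So the choice of alkyl group at this position can matter, even if only slightly. Isobutyl still cannot be told apart from cyclopentyl, with a 1.7-fold lower number from compound 1 to compound 3 (0.22 log units; within the scatter), and nothing measured here accounts for the difference between isopropyl and isobutyl.

Going by these compounds, it remains open whether a longer chain such as n-butyl would lower the number further or whether the gain stops at isobutyl. The compounds shown also cannot say how a chain ending in a hydroxyl or an amine would behave at this nitrogen.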